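A few compounds are considered here, and "the series" means these few. Any claim that something is new, unique, unknown or untested is made for them only; others in the source may bear on it.

Measured so far in an assay (Cricetulus griseus) for inhibition of aldehyde dehydrogenase, mitochondrial (Homo sapiens); a lower number here means a stronger inhibitor, a higher number a weaker inhibitor:
compound 1, `CCOC(=O)COc1ccc2c(=O)c(-c3ccc(O)cc3)coc2c1`: 130 nM
compound 2, `CCCCC(Oc1ccc2c(=O)c(-c3ccc(O)cc3)coc2c1)C(=O)OCC`: 4500 nM
compound 3, `O=C(O)CCCCCCCCCOc1ccc2c(=O)c(-c3ccc(O)cc3)coc2c1`: 50 nM

Compound 1 holds the second highest of the three numbers in this assay. Within the data shown here, its nearest neighbour is compound 3, which gives 50 nM; no single-point step between the two is defined, so only the two values themselves can be compared. The furthest is compound 2, reached by a 35-fold higher number from compound 1 to compound 2 (1.54 log units; beyond the scatter).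

Compound 4, `CC(C)Oc1ccc2c(=O)c(-c3ccc(O)cc3)coc2c1`, is not yet measured. It differs from compound 1 in one place: isopropyl in place of (ethoxycarbonyl)methyl on an oxygen on an aromatic ring. Among the measured compounds shown here, only one measured step touches this part of the molecule, a 35-fold higher number from compound 1 to compound 2 (1.54 log units; beyond the scatter), which enlarges the group on the saturated chain carbon bound to the oxygen on the aromatic ring and raises the number by a large margin. For the measured compounds named here, the change to compound 4 likewise puts a branched carbon on the oxygen on the aromatic ring, but at the same time the (ethoxycarbonyl)methyl group leaves entirely, and no measured pair shows what removing that group alone does. The expectation for compound 4 is therefore a moderate rise in the number beyond the scatter, a 3.1-fold higher number from compound 1 to compound 4 (0.49 log units; beyond the scatter), with wide uncertainty. The estimate for compound 4 is 400 nM, with a range from 100 nM to 2000 nM.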

Compound 4, half-maximal inhibitory concentration: 80 nM
The estimate for compound 4 lay 5.0-fold (0.70 log units) above the measured number, outside the stated range (below it).
By their numbers in this assay, from the lowest: compounds 3, 4 and 1 (each within the scatter of the next, the first and the last beyond it); then compound 2.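

In this assay, replacing the ester-bearing side group on the oxygen on the aromatic ring gives a 1.6-fold lower number from compound 1 to compound 4 (0.21 log units; within the scatter), so the step stays within the scatter even though 6 heavy atoms leave, 3 enter, and the carbonyl and both hydrogen-bond acceptors of (ethoxycarbonyl)methyl are gone. The large step of a 35-fold higher number from compound 1 to compound 2 (1.54 log units; beyond the scatter) therefore cannot be read as a general penalty for a branched carbon on this oxygen, since compound 4 also carries one there and stays within the scatter of compound 1. No measurement bears on why either change gives the result it does.

The compounds shown leave open what a methyl, a longer unbranched alkyl chain, or a short chain ending in a carboxylic acid or an amine would give on this oxygen. They also leave open whether a butyl on the saturated chain carbon raises the number on its own or only with the ethyl ester present, a question that a butyl-bearing chain ending in a carboxylic acid would help to settle.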